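The compounds below may be only part of what the source reports. "The series", "measured", "known", "first", "only" and "open" are said of these compounds alone.

Compound 2 `C=CCNC(=S)NCCCCn1nc(-c2ccccc2)ccc1=O` stands at a limit in a functional assay on the whole organism (stomach) with Rattus norvegicus as the target; on this read-out lower numbers stand for an effect already at smaller amounts and higher numbers for an effect only at larger amounts of compound: compound 2 gives > 100 mg/kg, which is a limit of the assay rather than a number. Compound 1 `C/N=C(/NC#N)NCCCCCn1nc(-c2ccccc2)ccc1=O` gives 100 mg/kg. For the measured compounds named here, only one measured step bears here, a number no lower from compound 1 to compound 2 (the limit leaves the size open), and its size stays open because the limit of > 100 mg/kg in this assay, at which 1 of the 2 values shown sits, applies to compound 2. Going by the values given here, compound 3 `C/N=C(/NC#N)N(C)CCCCn1nc(-c2ccccc2)ccc1=O` differs from compound 2 by a group of 8 heavy atoms (4 carbon, 4 nitrogen; no ring) in place of a group of 7 heavy atoms (4 carbon, 2 nitrogen, 1 sulfur; no ring), on a saturated chain carbon, four bonds along the chain from an aromatic nitrogen, which reverses that step and brings back a group close to the one compound 1 carries. Compound 3 is therefore expected near compound 1, at 100 mg/kg within 40 mg/kg to 250 mg/kg, a step of a number no higher from compound 2 to compound 3 (the limit leaves the size open).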

Compound 3, dose for half-maximal effect: > 100 mg/kg
Compound 3: only a limit was reported; the forecaster's own chance of this, stated with the estimate: 35%; the middle value lies on the limit itself.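

With the group of 8 heavy atoms (4 carbon, 4 nitrogen; no ring) in this place, four bonds along the chain from an aromatic nitrogen, this assay gives a number no lower from compound 1 to compound 3 (the limit leaves the size open). Compound 3 therefore stands at a limit, not at a number, just as compound 2 does. The sizes of the steps among these compounds cannot be read, because the values rest on a limit: the limit of > 100 mg/kg in this assay, at which 2 of the 3 values shown sit.

The compounds shown leave open how far compound 2 and compound 3 lie from that limit. They also leave open whether an amine or a carboxylic acid in this place would give a number in this assay.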